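A few compounds are considered here, and "the series" means these few. Any claim that something is new, unique, unknown or untested is made for them only; others in the source may bear on it.

In a functional assay on Shh Light II cells for inhibition of Sonic hedgehog protein (Mus musculus), read by reporter gene assay, with a stated time of 48 h, in the presence of a further agent that is not named here (on this read-out lower numbers stand for stronger inhibition and higher numbers for weaker inhibition), three compounds have so far been examined, and only one of them returned a number. Compound 1 `CCOc1cc(C(=O)Nc2ccc(Cl)c(-c3nc4ccccc4s3)c2)cc(OCC)c1OCC` is reported as "not active" (no number reported) in this assay. Compound 3 `CCOc1cc(C(=O)Nc2ccc(Cl)c(C3=NCCN3)c2)cc(OCC)c1OCC` is likewise reported as "not active" (no number reported) in this assay. For the measured compounds named here, compound 2 `O=C(Nc1ccc(Cl)c(-c2nc3ccccc3[nH]2)c1)c1ccc(F)cc1` is the single compound with a measured value: in this assay compound 2 gives 251 nM, so it stands alone as the reference point, with nothing to rank it against.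

Compound 4 `CN(C)c1ccc(C(=O)Nc2ccc(Cl)c(-c3nc4ccccc4[nH]3)c2)cc1` is the next compound to be measured. It differs from compound 2 in one place: dimethylamino in place of fluoro on an aromatic carbon. Going by the values given here, no pair of measured compounds differs by a single change, so there is no measured step from which the size of this change can be read; the structural change stands on its own. With that in mind, the step from compound 2 to compound 4 is expected to be small, most likely within the scatter of repeated measurements, and the expected step is a 1.1-fold lower number from compound 2 to compound 4 (0.06 log units; within the scatter). Compound 4 is therefore estimated to give 220 nM in this assay, with a range from 60 nM to 800 nM to allow for the lack of any guiding step.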

Compound 4, half-maximal inhibitory concentration: 190 nM
Compound 4: middle estimate off by 1.2-fold (0.06 log units), on the high side, and the stated range covers the measured number.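

In this assay, replacing fluoro with dimethylamino, on the ring carbon para to a large group, gives a 1.3-fold lower number from compound 2 to compound 4 (0.12 log units; within the scatter), so compound 2 and compound 4 cannot be told apart on this read-out. For the compounds shown here, this is the first measured single change, and it shows that this position can carry a group of 3 heavy atoms, one of them a hydrogen-bond acceptor, in place of a single fluorine without the number moving beyond the scatter. Nothing measured here explains why the two compounds read alike.

One pair cannot show how much room this position has, or whether the result would hold for a free amine, a carboxylic acid or a longer chain such as butoxy in the same place. Compound 1 and compound 3 each differ from compound 2 in more than one place. As far as these compounds go, both are reported as "not active", while compound 2 and compound 4 each gave a number, and it remains open which of those differences goes with that outcome.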